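The source may report more compounds than this note shows. Statements on the series, on what has been measured and on what is new or still open speak of the compounds shown alone.

Measured compounds:
compound 1 `C=CCOc1c(C)c(C)c2c(c1C)CCC(C)(COc1ccc(/C=C3\SC(=O)NC3=O)cc1)O2` — 42%
compound 2 `CC(C)=CCOc1c(C)c(C)c2c(c1C)CCC(C)(COc1ccc(/C=C3\SC(=O)NC3=O)cc1F)O2` — 87%
compound 3 `Cc1c(C)c2c(c(C)c1OC(=O)CCC(=O)O)CCC(C)(COc1ccc(/C=C3\SC(=O)NC3=O)cc1)O2` — 98%

In a functional assay on MCF7 cells (Homo sapiens), tested at 5 uM (a lower number here means a stronger effect, a higher number a weaker effect of the compound at the concentration tested), compound 1 stands lowest of the three, with compound 2 nearest and compound 3 furthest. Going by the values given here, the only measured single-point step, a number 56 percentage points higher from compound 1 to compound 3 (beyond the scatter), concerns a different group from the one at issue here. Compound 4 `CC(C)=CCOc1c(C)c(C)c2c(c1C)CCC(C)(COc1ccc(/C=C3\SC(=O)NC3=O)cc1)O2` differs from compound 1 by 2-methylprop-1-en-1-yl in place of vinyl on a saturated chain carbon bound to an oxygen on an aromatic ring. Among the compounds with values here, no measured pair carries this change alone; compound 2, which has the same 2-methylprop-1-en-1-yl group together with a second change, gives 87%, far above compound 1, so a rise beyond the scatter is expected. Compound 4 is therefore estimated to give 65% in this assay, between 40% and 90%. That estimate means a step of a number 23 percentage points higher from compound 1 to compound 4 (beyond the scatter).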

Compound 4, a percentage reported as activity, at one concentration (the size of the read-out at that concentration, not a potency): 21%
Compound 4: the middle estimate sits 44 percentage points above what was measured; measured number outside the range, below it.
By their numbers in this assay, from the lowest: compound 4; then compound 1; then compound 2; then compound 3.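

In this assay, the step of a number 21 percentage points lower from compound 1 to compound 4 (beyond the scatter) comes with 3-methylbut-2-en-1-yl in place of allyl on an oxygen on an aromatic ring, so this chain lowers the number rather than raising it. The step of a number 66 percentage points lower from compound 2 to compound 4 (beyond the scatter) comes with hydrogen in place of fluoro on an aromatic carbon, so the high number goes with the fluoro group and not with the chain. The step of a number 77 percentage points lower from compound 3 to compound 4 (beyond the scatter) sets 3-methylbut-2-en-1-yl against (2-carboxyethyl)carbonyl on that oxygen.

Nothing shown here explains these steps. From the compounds shown here alone, whether a longer chain such as geranyl, or an amine at the end of the chain, would lower the number further remains open.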